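A few compounds are considered here, and "the series" means these few. Any claim that something is new, unique, unknown or untested is made for them only; others in the source may bear on it.

Compound 2 `Clc1cccc2c(-c3ccc4ccccc4n3)c[nH]c12` is the starting point. In an ADME assay on microsomes from liver (Homo sapiens) for metabolic stability, using NADPH, with a stated time of 40 min, tested at 2 uM (a higher number here means that the compound lasts longer, a lower number that the compound disappears faster), compound 2 gives 0.283 h, the same number at the digits reported as compound 1 `Cc1cccc2c(-c3ccc4c(O)cccc4n3)c[nH]c12`, which gives 0.283 h. For the measured compounds named here, compound 3 `Cc1cccc2c(-c3ccc4c(F)cccc4n3)c[nH]c12` gives 0.217 h, and the one measured step, a 1.3-fold lower number from compound 1 to compound 3 (0.12 log units; within the scatter), lies within the scatter. Compound 4 `Fc1cc(Cl)c2[nH]cc(-c3ccc4ccccc4n3)c2c1` differs from compound 2 by fluoro in place of hydrogen on an aromatic carbon. The step from compound 1 to compound 3 also brings in a fluoro group, though on another ring and in place of a hydroxy rather than a hydrogen, so it bears only loosely on this change; it showed no movement beyond the scatter. Compound 4 is therefore expected to give 0.28 h, between 0.15 h and 0.5 h, which means an expected step of a 1.0-fold lower number from compound 2 to compound 4 (0.00 log units; within the scatter), none beyond the scatter.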

Compound 4, half-life: 0.383 h
Compound 4: middle estimate off by 1.4-fold (0.14 log units), on the low side; the range from low to high includes it.
By their numbers in this assay, from the lowest: compounds 3, 1, 2 and 4 (each within the scatter of the next).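

In this assay, fluoro in place of hydrogen on the aromatic carbon meta to the chloro group gives a 1.4-fold higher number from compound 2 to compound 4 (0.13 log units; within the scatter), so at this position the added fluoro moves the half-life no further than the scatter. This is the first step shown that puts fluoro in place of hydrogen, and on this ring rather than the other. Nothing available explains the half-life of compound 4. On these data alone, whether a methoxy group, a nitrile or an amine on this same carbon would leave the half-life as little changed remains open, as does whether fluoro here would act the same with methyl in place of the chloro group.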